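This account rests on a few compounds, and the source may have more. Where it says the series, first, only, none or still open, it means among the compounds named here.

Compound 3 `O=S(=O)(Nc1cccc(CO)c1)c1ccc(-c2ccc(Br)cc2F)cc1` is measured in a functional assay on J774 cells (Mus musculus) for cytotoxicity, read by resazurin assay, with a stated time of 72 h (a lower number here means a stronger inhibitor, a higher number a weaker inhibitor), at 1000 nM, the second highest of the three numbers shown: compound 1 `O=S(=O)(Nc1cccc(CO)c1)c1ccc(-c2ccccc2)cc1` gives 2200 nM, and compound 2 `O=S(=O)(Nc1ccc(CO)c(CO)c1)c1ccc(-c2ccc(F)cc2F)cc1` gives 150 nM. Among the compounds with values here, the only single-point step measured so far is a 2.2-fold lower number from compound 1 to compound 3 (0.34 log units; beyond the scatter). Compound 4 `O=S(=O)(Nc1cccc(CO)c1)c1ccc(-c2ccc(F)cc2F)cc1` differs from compound 3 by fluoro in place of bromo on an aromatic carbon. Within the data shown here, no measured step swaps these two halogens on their own; compound 2 carries the same 2,4-difluorophenyl group but also a second hydroxymethyl, so its number cannot be split between the two changes. The step expected in this assay is therefore small, a 1.1-fold lower number from compound 3 to compound 4 (0.05 log units; within the scatter), with no clear direction. Compound 4 is estimated at 900 nM, within a range from 350 nM to 2300 nM.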

Compound 4, half-maximal inhibitory concentration: 300 nM
For compound 4 the middle estimate is 3.0-fold (0.48 log units) above the measured one; the measured number lies below the stated range.
By their numbers in this assay, from the lowest: compounds 2 and 4 (each within the scatter of the next); then compound 3; then compound 1.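

In this assay, the identity of the halogen at this position matters: fluoro in place of bromo gives a 3.3-fold lower number from compound 3 to compound 4 (0.52 log units; beyond the scatter). Starting from the unsubstituted phenyl, the 2,4-difluorophenyl group gives a 7.3-fold lower number from compound 1 to compound 4 (0.87 log units; beyond the scatter). Removing the second hydroxymethyl gives a 2.0-fold higher number from compound 2 to compound 4 (0.30 log units; within the scatter), so that group shows no clear effect here.

Nothing available explains why these changes move the number. Going by these compounds, whether chloro, methoxy or an amine at this position would give a lower or higher number than fluoro remains open.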